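Trimming one phenyl from a triphenyl pyrazole acid

A few compounds are considered here, and "the series" means these few. Any claim that something is new, unique, unknown or untested is made for them only; others in the source may bear on it.

Compounds measured so far:
compound 1, `O=C(O)CCCCCCCn1nc(-c2ccccc2)c(-c2ccccc2)c1-c1ccccc1`, 3400 nM
compound 2, `O=C(O)CCCCCCCCn1nc(-c2ccccc2)c(-c2ccccc2)c1-c1ccccc1`, 400 nM

The two compounds share a core carrying three phenyl groups and an acid chain; they differ only in the chain length. In a functional assay for inhibition, with Homo sapiens as the target (a lower number here means a stronger inhibitor, a higher number a weaker inhibitor), compound 2 gives the lowest of the two numbers, and the nearest is compound 1, reached by the step of an 8.5-fold lower number from compound 1 to compound 2 (0.93 log units; beyond the scatter).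

Compound 3, `CCc1c(-c2ccccc2)nn(CCCCCCCCC(=O)O)c1-c1ccccc1`, keeps the longer chain of compound 2 and changes the core instead: ethyl in place of phenyl on an aromatic carbon. Going by the values given here, no measured step touches the phenyl groups; the only step known, an 8.5-fold lower number from compound 1 to compound 2 (0.93 log units; beyond the scatter), concerns the chain alone, so it cannot be read as a guide for this change. The two measured compounds give no evidence either way on whether each of the three phenyl groups matters. Taking the unknown at face value, compound 3 is expected to lie somewhat above compound 2 in this assay, with wide uncertainty, as the step of a 2.5-fold higher number from compound 2 to compound 3 (0.40 log units; beyond the scatter).

Compound 3 is therefore estimated at 1000 nM, within a range from 250 nM to 4000 nM.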

Compound 3, half-maximal inhibitory concentration: > 79000 nM
Compound 3 was reported as a limit; the forecaster's own chance of this, stated with the estimate: 5%; middle value at least 79-fold (1.89 log units) from the limit.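

In this assay, putting ethyl in place of phenyl on this aromatic carbon gives an at least 190-fold higher number from compound 2 to compound 3 (2.29 log units; beyond the scatter), a far larger change than the one seen on the chain, an 8.5-fold lower number from compound 1 to compound 2 (0.93 log units; beyond the scatter). Going by these compounds alone, for this series, then, the phenyl at this position cannot be swapped for ethyl without a heavy loss of inhibition, something the chain change between the earlier compounds could not reveal. Compound 3 is reported only as a limit of the assay, not as a number: the limit of > 79000 nM in this assay, at which 1 of the 3 values shown sits.

The change removes a phenyl of 6 heavy atoms and its aromatic ring and brings in an ethyl of 2 heavy atoms with no ring, so the compounds shown cannot say whether the ring itself or simply the larger group matters, and no cause for the loss can be given. On these data alone, a cyclohexyl group at this carbon would keep a ring without the aromatic character and a pyridyl group would keep an aromatic ring with a nitrogen in it, and the part played by the other two phenyl groups of the shared core also stays open.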